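The source may report more compounds than this note shows. Statements on the series, on what has been measured and on what is new or still open speak of the compounds shown alone.

In an assay on microsomes from liver for inhibition of acyl-CoA desaturase 1 (Rattus norvegicus) (on this read-out higher numbers stand for weaker inhibition and lower numbers for stronger inhibition), compound 3 `Oc1nnc(-c2ccc(N3CCC(Oc4ccccc4C(F)(F)F)CC3)nn2)s1` gives 6.1 nM, the lowest of the three numbers measured. Compound 1 `c1cc2c(c(OC3CCN(c4ccc(-n5ccnc5)nn4)CC3)c1)CCC2` gives 10 nM, a value within the scatter of compound 3, whereas compound 2 `N#Cc1ccccc1OC1CCN(c2ccc(-n3ccnc3)nn2)CC1` gives 236 nM. Among the measured compounds shown here, the only measured step, a 24-fold higher number from compound 1 to compound 2 (1.37 log units; beyond the scatter), changes the group on an oxygen on a saturated carbon, a different part of the shared core. Compound 4 `Cc1nnc(-c2ccc(N3CCC(Oc4ccccc4C(F)(F)F)CC3)nn2)s1` differs from compound 3 by methyl in place of hydroxy on an aromatic carbon. For the measured compounds named here, no measured step touches this ring, so nothing here shows how this assay responds to such a swap. Because compound 3 gives 6.1 nM, compound 4 is expected to stay near it, with a step of a 1.1-fold higher number from compound 3 to compound 4 (0.06 log units; within the scatter) expected to lie within the scatter. Compound 4 is therefore estimated at 7 nM, with a range from 2.5 nM to 20 nM.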

Compound 4, half-maximal inhibitory concentration: 2.3 nM
Beside the measured number, compound 4's estimate is 3.0-fold (0.48 log units) above it, outside the stated range (below it).
By their numbers in this assay, from the lowest: compound 4; then compounds 3 and 1 (each within the scatter of the next); then compound 2.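

In this assay, among the compounds shown here, going from 5-hydroxy-1,3,4-thiadiazol-2-yl to 5-methyl-1,3,4-thiadiazol-2-yl gives a 2.7-fold lower number from compound 3 to compound 4 (0.42 log units; beyond the scatter) and is the first measured sign that this position affects the result. Strong inhibition persists without the hydroxy, so in this pair that group is not required for it. Nothing measured here explains the drop. On these data alone, whether an amine, an ethyl group or a carboxylic acid at this position would lower the number further remains open. As far as these compounds go, this change is also seen in one pair only, so its size on other compounds is unknown.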